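Quinazolinone series: removing the bromo substituent from compound 3

This account rests on a few compounds, and the source may have more. Where it says the series, first, only, none or still open, it means among the compounds named here.

Measured so far in a functional assay on the whole organism (strain albino) with Rattus norvegicus as the target, in the maximal electroshock model, with a stated time of 1 h, at a dose of 30 mg/kg by the intraperitoneal route; a lower number here means less inhibition, a higher number more inhibition at the dose given (going by the name of the read-out):
compound 1 `Cc1nc2ccc(Br)cc2c(=O)n1NCc1nnc(N2C(=O)CSC2c2ccc(O)cc2)s1` gives 60%
compound 2 `Cc1nc2ccccc2c(=O)n1NCc1nnc(/N=C/c2ccc(N(C)C)cc2)s1` gives 50%
compound 3 `CCOC(=O)CNn1c(C)nc2ccc(Br)cc2c1=O` gives 20%

Compound 3 stands lowest of the three numbers in this assay; compound 2 sits nearest, beyond the scatter above it, and compound 1 furthest, also beyond the scatter. Going by the values given here, compounds 1 and 2 differ from compound 3 in more than one place, so no single step between measured compounds is available to guide the next change.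

Compound 4 `CCOC(=O)CNn1c(C)nc2ccccc2c1=O` differs from compound 3 in one place only: hydrogen in place of bromo on an aromatic carbon. Among the compounds with values here, no comparable step has been measured, so the expected step is small, within the scatter, with at most a slight downward lean a number 5 percentage points lower from compound 3 to compound 4 (within the scatter). Compound 4 is estimated at 15% in this assay, with a range from 0% to 40%.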

Compound 4, a percentage reported as inhibition, in the whole organism at one dose (the size of the read-out at that dose, not a potency): 20%
Estimate against measurement, compound 4: 5 percentage points below; low and high end bracket the measured number.
By their numbers in this assay, from the lowest: compounds 3 and 4 (each within the scatter of the next); then compounds 2 and 1 (each within the scatter of the next).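

In this assay, going by these compounds alone, the exchange of bromo for hydrogen on this aromatic carbon gives no change at the digits printed from compound 3 to compound 4 (within the scatter) and is the first single-place step. With the side chain of compound 3 kept, the bromo is therefore not needed to hold the read-out at this position, and the low level stays with or without it. No measurement at hand bears on why the exchange leaves the number in place.

Open, from the compounds shown here alone, is whether a methoxy, an amine or a carboxylic acid on this carbon would move the number beyond the scatter. Also open, going by these compounds, is whether the same exchange stays as silent with the longer side chain of compound 1.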